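A few compounds are considered here, and "the series" means these few. Any claim that something is new, unique, unknown or untested is made for them only; others in the source may bear on it.

Within the data shown here, compound 2 `CCCCCCCNc1cc(-c2ccccc2)c(-c2ccccc2)nn1` gives 55000 nM in an assay on microsomes from liver for inhibition of sterol O-acyltransferase 1 (Rattus norvegicus) (on this read-out higher numbers stand for weaker inhibition and lower numbers for stronger inhibition), the highest of the two numbers measured so far. Its nearest neighbour is compound 1 `CCCCCCNc1cc(-c2ccccc2)c(-c2ccccc2)nn1`, which gives 24000 nM in this assay; the step of a 2.3-fold higher number from compound 1 to compound 2 (0.36 log units; beyond the scatter) is the only one measured, and it concerns the chain, not the nitrogen. Compound 3 `CCCCCC(=O)Nc1cc(-c2ccccc2)c(-c2ccccc2)nn1` differs from compound 2 by pentylcarbonyl in place of heptyl on a nitrogen on an aromatic ring. Among the measured compounds shown here, no measured step touches this change directly: the one step measured alters the chain length and offers no guide to what happens when a carbonyl enters at the ring nitrogen. Compound 3 is therefore expected to sit near compound 2 in this assay, with no step beyond the scatter predicted with any confidence, and the range for compound 3 is kept wide, a 1.4-fold lower number from compound 2 to compound 3 (0.14 log units; within the scatter). The estimate for compound 3 in this assay is 40000 nM, between 8000 nM and 200000 nM.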

Compound 3, half-maximal inhibitory concentration: > 300000 nM
Compound 3 ended at the assay's limit; the forecaster's own chance of this, stated with the estimate: 20%; at least 7.5-fold (0.87 log units) between middle value and limit.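

The reading for compound 3 in this assay is a limit of the assay and not a number: the limit of > 300000 nM in this assay, at which 1 of the 3 values shown sits. Pentylcarbonyl in place of heptyl on a nitrogen on an aromatic ring gives an at least 5.4-fold higher number from compound 2 to compound 3 (0.73 log units; beyond the scatter), and pentylcarbonyl in place of hexyl at the same place gives an at least 12-fold higher number from compound 1 to compound 3 (1.09 log units; beyond the scatter). Compound 1 and compound 2 differ only in chain length, so only now does it appear that a carbonyl on this nitrogen goes with weaker inhibition in this assay, with both steps beyond the scatter.

As far as these compounds go, the true size of these steps stays open, since compound 3 ended at a limit. Also open, from the compounds shown here alone, is whether a shorter acyl group such as acetyl, a urea or a sulfonamide on this nitrogen would read the same way, and how a butyl chain would read.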